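This account rests on a few compounds, and the source may have more. Where it says the series, first, only, none or still open, it means among the compounds named here.

Compound 2 `Cc1cc(NS(=O)(=O)c2c([N+](=O)[O-])cc([N+](=O)[O-])cc2C(F)(F)F)c(Cl)cc1Cl` has the shared core of compound 1 `O=[N+]([O-])c1cc(C(F)(F)F)cc([N+](=O)[O-])c1Sc1ccc(Cl)cc1Cl`, which in a physicochemical assay for lipophilicity, measured as octanol-water partition (a lower number here means a more polar compound, a higher number a more lipophilic compound), gives 6.73. In this assay compound 2 gives 6.44, a number within the scatter of compound 1, so the two are not separable on this measure. Compound 3 `O=[N+]([O-])c1cc([N+](=O)[O-])c(S(=O)(=O)Nc2cccc(F)c2)c(C(F)(F)F)c1` is not yet measured. It differs from compound 2 in one place: 3-fluorophenyl in place of 2,4-dichloro-5-methylphenyl on a sulfonamide nitrogen. For the measured compounds named here, no measured step describes this exchange, so the expectation rests on the change alone. A large step downward from compound 2 to compound 3 is expected, a number 1.84 log units lower from compound 2 to compound 3 (beyond the scatter). Compound 3 is therefore estimated at 4.6, within the range 4 to 5.2.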

Compound 3, partition coefficient: 4.39
Estimate against measurement, compound 3: 0.21 log units above; low and high end bracket the measured number.
By their numbers in this assay, from the lowest: compound 3; then compounds 2 and 1 (each within the scatter of the next).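

In this assay, the group on the sulfonamide nitrogen is a position where one exchange moves the number well beyond the scatter: 3-fluorophenyl in place of 2,4-dichloro-5-methylphenyl gives a number 2.05 log units lower from compound 2 to compound 3 (beyond the scatter). This sensitivity rests on a single exchange at this position. Nothing at hand accounts for the size of the step.

Which of the chlorines, the methyl or the fluorine carries the step stays open, as all of them change together. Also open, from the compounds shown here alone, is how an amine or a carboxylic acid on this phenyl ring would read.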